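Three Fluorophenyl Carbamates and an Untested Fourth

This account rests on a few compounds, and the source may have more. Where it says the series, first, only, none or still open, it means among the compounds named here.

Measured compounds:
compound 1, `CC(C)=CCC1Cc2c(O)cc(=O)n(CCCO)c2CC1(C)C`: 0%
compound 2, `CC(C)=CCC1Cc2c(OC(=O)Nc3ccc(F)cc3)cc(=O)n(CCCO)c2CC1(C)C`: 0%
compound 3, `CC(C)=CCC1Cc2c(OC(=O)Nc3cccc(F)c3)cc(=O)n(CCCO)c2CC1(C)C`: 0%

All three compounds were tested in a functional assay on PANC-1 cells (Homo sapiens) for inhibition, read by MTT assay, with a stated time of 24 h, tested at 10 uM; on this read-out lower numbers stand for less inhibition and higher numbers for more inhibition at the one concentration tested (going by the name of the read-out). Compound 1, which carries a free hydroxyl on its aromatic ring, gives 0%. Adding a carbamate to that oxygen brings no shift: the step of no change at the digits printed from compound 1 to compound 2 (within the scatter) and the step of no change at the digits printed from compound 1 to compound 3 (within the scatter) both stay within the scatter. Between the two carbamates themselves the step of no change at the digits printed from compound 2 to compound 3 (within the scatter) is likewise flat. Going by the values given here, compound 3 therefore stands level with compound 1 and compound 2 in this assay, with no compound standing apart from the others.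

Compound 4, `CC(C)=CCC1Cc2c(OC(=O)Nc3ccccc3F)cc(=O)n(CCCO)c2CC1(C)C`, differs from compound 3 in one place: 2-fluorophenyl in place of 3-fluorophenyl on an amide-type nitrogen. The step that bears on this change is the one already seen between the two fluorophenyl isomers, no change at the digits printed from compound 2 to compound 3 (within the scatter), which showed nothing beyond the scatter; the steps from compound 1 to its carbamates were equally flat. On that basis the step of no change at the digits printed from compound 3 to compound 4 (within the scatter) is expected to be none beyond the scatter. Compound 4 is accordingly estimated to give 0% in this assay, within a range of 0% to 10%.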

Compound 4, a percentage reported as inhibition, at one concentration (the size of the read-out at that concentration, not a potency): 0%
The estimate for compound 4 equals the measured number at the digits printed; the measured number falls inside the stated range.
By their numbers in this assay, from the lowest: compounds 1, 2, 3 and 4 (each within the scatter of the next).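

In this assay, the 2-fluorophenyl group on the amide-type nitrogen completes the set of three fluorophenyl isomers, and the new isomer stands apart from neither of the others: the result is no change at the digits printed from compound 3 to compound 4 (within the scatter), and likewise no change at the digits printed from compound 2 to compound 4 (within the scatter). The (2-fluorophenyl)carbamoyl group in place of hydrogen on the oxygen on the aromatic ring behaves as the other two carbamoyl groups do, with no change at the digits printed from compound 1 to compound 4 (within the scatter), so among these compounds, where the fluorine stands on the phenyl ring makes no difference to the read-out. No independent measurement is available that bears on this flat result.

What the compounds shown leave open is whether any replacement on the amide-type nitrogen can move the read-out at all, since all of the changes seen here swap one fluorophenyl isomer for another or add a fluorophenyl carbamoyl group to the oxygen. A chlorophenyl, a methoxyphenyl, an aminophenyl or a cyclohexyl group on that nitrogen would test this, as would a carboxylic acid on the phenyl ring.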